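Shifting a Methyl Group: From Compound 3 to Compound 4

A few compounds are considered here, and "the series" means these few. Any claim that something is new, unique, unknown or untested is made for them only; others in the source may bear on it.

Three ureas built on one shared core were measured in a functional assay on HCC827 cells (Homo sapiens) for inhibition, read by MTT assay, with a stated time of 48 h, tested at 10 uM; on this read-out lower numbers stand for less inhibition and higher numbers for more inhibition at the one concentration tested (going by the name of the read-out). Compound 1 `COc1cc(NC(=O)Nc2cc(Nc3cc(Br)ccc3OC)ncn2)cc(OC)c1` gives 76.3%, compound 2 `CCc1cccc(Nc2cc(NC(=O)Nc3cc(OC)cc(OC)c3)ncn2)c1` gives 52.6%, and compound 3 `COc1cc(NC(=O)Nc2cc(Nc3ccc(C)c(F)c3)ncn2)cc(OC)c1` gives 72%. Compound 3 stands second highest of the three numbers: its gap to compound 1 is within the scatter, while a number 19.4 percentage points higher from compound 2 to compound 3 (beyond the scatter) and a number 23.7 percentage points lower from compound 1 to compound 2 (beyond the scatter) are the two steps that lie beyond it. Compound 4 `COc1cc(NC(=O)Nc2cc(Nc3cc(C)cc(F)c3)ncn2)cc(OC)c1` differs from compound 3 only in the group carried on the nitrogen: 3-fluoro-5-methylphenyl in place of 3-fluoro-4-methylphenyl on a nitrogen on an aromatic ring. Among the compounds with values here, no measured step bears directly on this change; every step seen so far exchanges one aryl group for a different one, and the step between the two most similar groups, a number 4.3 percentage points lower from compound 1 to compound 3 (within the scatter), stays within the scatter. On that basis the writer expects no step beyond the scatter in this assay, and the expected step is a number 4 percentage points lower from compound 3 to compound 4 (within the scatter). Compound 4 is therefore estimated at 68%, with a range from 50% to 84%.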

Compound 4, a percentage reported as inhibition, at one concentration (the size of the read-out at that concentration, not a potency): 62.1%
For compound 4 the middle estimate is 5.9 percentage points above the measured one; the range from low to high includes it.
By their numbers in this assay, from the lowest: compounds 2, 4, 3 and 1 (each within the scatter of the next, the first and the last beyond it).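

In this assay, within the data shown here, the change from 3-fluoro-4-methylphenyl to 3-fluoro-5-methylphenyl keeps the same atoms on the nitrogen and gives a number 9.9 percentage points lower from compound 3 to compound 4 (within the scatter), the first step here that rearranges one aryl group instead of exchanging it for a different one. That step cannot separate the two isomers, yet their relations to the other compounds differ: compound 4 shows a number 9.5 percentage points higher from compound 2 to compound 4 (within the scatter), a gap that compound 3 did not share with compound 2. It also shows a number 14.2 percentage points lower from compound 1 to compound 4 (beyond the scatter), whereas compound 3 stayed within the scatter of compound 1. Nothing available gives a reason for these numbers. Going by these compounds, whether an amine or a carboxylic acid in place of the methyl group would produce a step beyond the scatter remains open.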